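The source may hold more compounds than are shown below. What is called first, only, known or untested is meant among the compounds shown, and "the series" means these compounds.

Of the compounds shown here, three share one core and have been tested in a functional assay on CHO cells for agonist activity at adenosine receptor A1 (Homo sapiens), read by fluorescence and ERK phosphorylation, with stated times of 30 min and 1.5 h, tested at 3 uM; on this read-out lower numbers stand for a weaker effect and higher numbers for a stronger effect at the one concentration tested. Compound 1 `Nc1scc(-c2cccc(Br)c2)c1C(=O)c1ccccc1` gives 67%, compound 2 `Nc1scc(-c2cccc(C(F)(F)F)c2)c1C(=O)c1ccc(Cl)cc1` gives 64%, and compound 3 `Nc1scc(-c2ccc(F)cc2)c1C(=O)c1ccc(Cl)cc1` gives 62%. In this assay compound 3 thus sits alongside the other two, its number within the usual scatter of both compound 2 and compound 1. Compound 4 `Nc1scc(-c2cccc(Br)c2)c1C(=O)c1ccc(Cl)cc1` has not yet been measured; it differs from compound 3 in one place: 3-bromophenyl in place of 4-fluorophenyl on an aromatic carbon. Compound 1 already carries the 3-bromophenyl group and gives 67%, a number close to that of compound 3, so no step beyond the scatter is expected. The estimated value for compound 4 in this assay is 65%, between 54% and 76%, an expected step of a number 3 percentage points higher from compound 3 to compound 4 (within the scatter).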

Compound 4, a percentage reported as activity, at one concentration (the size of the read-out at that concentration, not a potency): 62%
Estimate against measurement, compound 4: 3 percentage points above; measured number inside the range.
By their numbers in this assay, from the lowest: compounds 3, 4, 2 and 1 (each within the scatter of the next).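

In this assay the step is no change at the digits printed from compound 3 to compound 4 (within the scatter) when 3-bromophenyl takes the place of 4-fluorophenyl, so at this position the two aryl groups cannot be told apart. The other two new comparisons read a number 2 percentage points lower from compound 2 to compound 4 (within the scatter) for bromo in place of trifluoromethyl and a number 5 percentage points lower from compound 1 to compound 4 (within the scatter) for chloro in place of hydrogen. Nothing measured here gives a reason for these results.

As far as these compounds go, whether an amine, a carboxylic acid or a longer chain at this position would move the number beyond the scatter stays open. The single tested concentration also says nothing about potency.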